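Cyanoalkoxy chain length in an acetophenone series

The source may hold more compounds than are shown below. What is called first, only, known or untested is meant among the compounds shown, and "the series" means these compounds.

Measured compounds:
compound 1 `CCc1cc(C(C)=O)c(O)cc1OCCCCC#N` 92%
compound 2 `CCc1cc(C(C)=O)c(O)cc1OCCCCCCC#N` 103%
compound 3 `C=CCc1cc(C(C)=O)c(O)cc1OCC#N` 20%

In an assay on isolated protein for inhibition of leukotriene B4 receptor 1 (Homo sapiens), tested at 10 uM (on this read-out higher numbers stand for more inhibition at the one concentration tested (going by the name of the read-out) and lower numbers for less inhibition), compound 1 gives 92% and compound 2 gives 103%. The change between them, 2-cyanoethyl in place of cyano on a saturated chain carbon, four bonds along the chain from an oxygen on an aromatic ring, gives a number 11 percentage points higher from compound 1 to compound 2 (beyond the scatter). Compound 3 sits lowest of the three with 20%. The difference between the cores of compound 1 and compound 3 is not broken down here.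

Compound 4 `C=CCc1cc(C(C)=O)c(O)cc1OCCCC#N` is not yet measured. It differs from compound 3 by 2-cyanoethyl in place of cyano on a saturated chain carbon bound to an oxygen on an aromatic ring. The place differs from the earlier change, where the saturated chain carbon lay four bonds along the chain from the oxygen, so this is the same kind of change, not the same one. A step larger than a number 11 percentage points higher from compound 1 to compound 2 (beyond the scatter) is expected here, because compound 3 gives 20% while compound 1, with a longer chain, gives 92%. The expected step is a number 40 percentage points higher from compound 3 to compound 4 (beyond the scatter). Compound 4 is estimated at 60%, with a range from 30% to 90%.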

Compound 4, a percentage reported as inhibition, at one concentration (the size of the read-out at that concentration, not a potency): 47%
For compound 4 the middle estimate is 13 percentage points above the measured one; the range from low to high includes it.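

In this assay the swap of cyano for 2-cyanoethyl on the core of the allyl compounds gives a number 27 percentage points higher from compound 3 to compound 4 (beyond the scatter). Set beside the earlier step, the direction carries over to the new core but the size does not: the same change on two cores in this assay, a number 11 percentage points higher (beyond the scatter) from compound 1 to compound 2 and a number 27 percentage points higher (beyond the scatter) from compound 3 to compound 4, 16 percentage points apart, beyond the scatter of two such steps

This does not separate core from place, as the new step sits on a saturated chain carbon bound to an oxygen on an aromatic ring, the earlier one four bonds along the chain from that oxygen, and each core offers a single pair.

Open, on these data alone, is whether a longer chain than 3-cyanopropoxy on the core of compound 4 keeps raising the number, and whether the same swap at one shared place gives equal steps on both cores. Also open, as far as these compounds go, is whether the nitrile at the chain end matters at all, which a carboxylic acid, an amide or an amine in its stead would address.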